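The source may report more compounds than this note shows. Statements on the series, on what has been measured and on what is new or still open speak of the compounds shown alone.

Compound 3 `Cc1nc2c3ccccc3ccc2c2nc3c(ccc4ccccc43)c(C)c12`, the methyl-bearing member of this set, is known in a functional assay on AGS cells (Homo sapiens) for cytotoxicity, read by MTT assay, with a stated time of 48 h (a lower number here means a stronger inhibitor, a higher number a weaker inhibitor), only as a limit: the value for compound 3 is > 80000 nM, (the limit of > 80000 nM in this assay, at which 1 of the 3 values shown sits). Two measured steps lead to compound 3 from an analogue carrying an aryl group at the same position. Compound 1 `Cc1nc2c3ccccc3ccc2c2nc3c(ccc4ccccc43)c(-c3ccccc3Cl)c12` gives 52500 nM, and exchanging its aryl for methyl yields an at least 1.5-fold higher number from compound 1 to compound 3 (0.18 log units; that floor lies within the scatter). Compound 2 `Cc1nc2c3ccccc3ccc2c2nc3c(ccc4ccccc43)c(-c3cccc([N+](=O)[O-])c3)c12` gives 25500 nM, and the same exchange yields an at least 3.1-fold higher number from compound 2 to compound 3 (0.49 log units; beyond the scatter). Compound 4 `Cc1nc2c3ccccc3ccc2c2nc3c(ccc4ccccc43)c(-c3ccccc3)c12` runs the opposite way: phenyl in place of methyl on an aromatic carbon. On this basis compound 4 is expected to show a lower number than compound 3, a step estimated at an at least 1.7-fold lower number from compound 3 to compound 4 (0.24 log units; that floor lies within the scatter). Compound 4 is accordingly estimated at 45000 nM, within a range from 20000 nM to 100000 nM.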

Compound 4, half-maximal inhibitory concentration: > 80000 nM
Compound 4 gave a limit, no number; the forecaster's own chance of this, stated with the estimate: 25%; middle value at least 1.7-fold (0.24 log units) away from the limit.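

In this assay compound 4, like compound 3, gives only a limit, and the step between these two cannot be read: the limit of > 80000 nM in this assay, at which 2 of the 4 values shown sit. A plain phenyl at this position therefore gives no measured number, and the numbers seen so far come only with a substituted phenyl. Hydrogen in place of nitro gives an at least 3.1-fold higher number from compound 2 to compound 4 (0.49 log units; beyond the scatter), while hydrogen in place of chloro gives an at least 1.5-fold higher number from compound 1 to compound 4 (0.18 log units; that floor lies within the scatter).

Going by these compounds, how much the chloro contributes remains open. So does whether an amine or a carboxylic acid on that phenyl would give a number, as the nitro does in compound 2.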